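A few compounds are considered here, and "the series" means these few. Any claim that something is new, unique, unknown or untested is made for them only; others in the source may bear on it.

Compound 3 `CN(C)CCCCCSC1=Nc2ccccc2C(CC(=O)NCc2ccc(F)cc2)N1c1ccc(-c2ccccc2)cc1` was tested in a functional assay on HCT-116 cells (Homo sapiens) for cytotoxicity, read by MTT assay, with a stated time of 48 h (on this read-out lower numbers stand for stronger inhibition and higher numbers for weaker inhibition), and gives 6400 nM. Compound 1 `CN(C)CCCCCSC1=Nc2ccccc2C(CC(=O)NCc2ccccc2)N1c1ccc(-c2ccccc2)cc1` carries hydrogen where compound 3 carries fluoro; in this assay compound 1 gives 9600 nM, and the step of a 1.5-fold lower number from compound 1 to compound 3 (0.18 log units; within the scatter) lies within the scatter. Compound 2 `O=C(CC1c2ccccc2N=C(SCCCCCN2CCCC2)N1c1ccccc1)NCc1ccc(F)cc1` gives 27100 nM in this assay, a number beyond the scatter from that of compound 3; compound 2 differs from compound 3 in two places at once, so this gap cannot be laid on either change alone.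

Compound 4 `CN(C)CCCCCSC1=Nc2ccccc2C(CC(=O)NCc2ccc(F)cc2)N1c1ccccc1` is not yet measured. It differs from compound 3 by hydrogen in place of phenyl on an aromatic carbon. Going by the values given here, no measured pair isolates this change. Among the compounds with values here, compound 2, the only measured compound with plain phenyl on that nitrogen, gives the highest number seen here, which points, weakly, toward a higher number for compound 4. The step of a 2.3-fold higher number from compound 3 to compound 4 (0.37 log units; beyond the scatter) is therefore expected in this assay, and compound 4 is estimated at 15000 nM, with a range from 6000 nM to 40000 nM.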

Compound 4, half-maximal inhibitory concentration: 38800 nM
Compound 4: the middle estimate sits 2.6-fold (0.41 log units) below what was measured; the measured number falls inside the stated range.
By their numbers in this assay, from the lowest: compounds 3 and 1 (each within the scatter of the next); then compounds 2 and 4 (each within the scatter of the next).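

Cutting 4-phenylphenyl back to phenyl is the first change at this position that stands alone between two measured compounds: in this assay it gives a 6.1-fold higher number from compound 3 to compound 4 (0.78 log units; beyond the scatter), whereas the earlier fluoro step stayed within the scatter. With plain phenyl present in both compounds, the swap to dimethylamino from pyrrolidin-1-yl gives a 1.4-fold higher number from compound 2 to compound 4 (0.16 log units; within the scatter), so the amine change shows no clear effect in this pair, and the high number of compound 2 no longer stands out from that of compound 4. Nothing available explains why the outer phenyl ring matters to this read-out.

As far as these compounds go, it remains open whether a phenyl ring is needed at this position, or whether a cyclohexyl ring or a bromine atom would serve as well. The amine swap also remains unread alongside 4-phenylphenyl, where the outcome could differ.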